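This account rests on a few compounds, and the source may have more. Where it says the series, first, only, none or still open, it means among the compounds named here.

Measured so far in an ADME assay on NIH3T3 cells (Mus musculus) for cytotoxicity, read by MTT assay, with a stated time of 24 h; on this read-out higher numbers stand for weaker inhibition and lower numbers for stronger inhibition:
- compound 1, `Cn1cnnc1SCCc1nnc(SCC(=O)Nc2ccc(F)cc2)o1`: > 500 ug/mL
- compound 2, `Cn1cnnc1SCCc1nnc(SCC(=O)Nc2ccccc2)o1`: > 500 ug/mL

Both figures are limits of this assay rather than numbers. Compound 2 therefore stands at the limit of > 500 ug/mL in this assay, at which 2 of the 2 values shown sit, with no readable position of its own. Among the measured compounds shown here, the one measured step, a step that the two limits leave unreadable from compound 1 to compound 2, is a change of hydrogen in place of fluoro on an aromatic carbon whose size the two limits hide, so it tells nothing about how far either compound lies beyond the limit.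

Compound 3, `COc1ccc(NC(=O)CSc2nnc(CCSc3nncn3C)o2)cc1`, differs from compound 2 by methoxy in place of hydrogen on an aromatic carbon. For the measured compounds named here, no measured step bears directly on a methoxy in place of hydrogen, and the only step available is itself unreadable. With both measured compounds sitting at the limit, compound 3 is expected to do the same, a step that the limit leaves unreadable from compound 2 to compound 3 in this assay. Compound 3 is estimated at 600 ug/mL, within a range of 350 ug/mL to 1500 ug/mL, most probably reported again only as a limit.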

Compound 3, half-maximal inhibitory concentration: > 500 ug/mL
Compound 3 gave a limit, no number; the forecaster's own chance of this, stated with the estimate: 85%; the middle value is on the limit's open side.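

In this assay compound 3, like compound 1 and compound 2, gives only a limit, so no step among these three compounds can be read. From the compounds shown here alone, how far each lies beyond that limit, and whether fluoro, hydrogen or methoxy on the aromatic carbon makes any difference, stays open.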